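Bromomethyl for ethoxycarbonyl: working notes on compound 4

The compounds below may be only part of what the source reports. "The series", "measured", "known", "first", "only" and "open" are said of these compounds alone.

In a functional assay on DU-145 cells (Homo sapiens) for cytotoxicity, read by MTT assay, with a stated time of 72 h (on this read-out higher numbers stand for an effect only at larger amounts of compound and lower numbers for an effect already at smaller amounts), compound 1 `CCc1cccc2c(OC)c(-c3occ(C)c3C(=O)OC)ccc12` gives 2.2 ug/mL and compound 2 `CCOC(=O)c1c(C)coc1-c1ccc2c(CC)cccc2c1OC` gives 2.2 ug/mL. Compound 2 therefore stands level with compound 1, its nearest neighbour on the numbers. In this assay, compound 3 `CCOc1c(-c2occ(C)c2CO)ccc2c(CC)cccc12` gives > 10 ug/mL, and this value is a limit, not a number.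

The next structure is compound 4 `CCc1cccc2c(OC)c(-c3occ(C)c3CBr)ccc12`, and the change is bromomethyl in place of ethoxycarbonyl on an aromatic carbon. In words, bromomethyl takes the place of ethoxycarbonyl on an aromatic carbon, next to the ring atom that bears a methyl group.

Among the measured compounds shown here, the only measured step is no change at the digits printed from compound 1 to compound 2 (within the scatter). That step leaves the carbonyl in place, so it bears only weakly on removing the whole ethoxycarbonyl group. For the measured compounds named here, no measured step covers that replacement. The limit reached by compound 3 at > 10 ug/mL shows that a compound of this series can leave the measured range, so the upper end of the expectation is kept wide.

No shift beyond the scatter is expected in this assay, though a move towards higher numbers is the likelier error. The estimated step is a 1.4-fold higher number from compound 2 to compound 4 (0.13 log units; within the scatter). For compound 4 the expected value is 3 ug/mL, with an estimated range from 0.8 ug/mL to 12 ug/mL.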

Compound 4, concentration for half-maximal effect: > 10 ug/mL
Compound 4: a limit, no number; the forecaster's own chance of this, stated with the estimate: 20%; middle value at least 3.3-fold (0.52 log units) from the limit.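

In this assay the earlier pair showed only no change at the digits printed from compound 1 to compound 2 (within the scatter) when the alkyl end of the ester changed. Exchanging the whole ester for bromomethyl is the only one-place change shown that moves the read-out beyond the scatter: with ethoxycarbonyl leaving it gives an at least 4.5-fold higher number from compound 2 to compound 4 (0.65 log units; beyond the scatter) and with methoxycarbonyl leaving it gives an at least 4.5-fold higher number from compound 1 to compound 4 (0.65 log units; beyond the scatter) on the same shared core. Going by these compounds, this place on the five-membered aromatic ring therefore accepts a change at the alkyl end of the ester in these compounds but not this exchange, and the full size of the shift stays unknown because compound 4 sits at a limit, not at a number: the limit of > 10 ug/mL in this assay, at which 2 of the 4 values shown sit.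

The compounds shown leave open whether the shift follows from the loss of the carbonyl group or from the bromomethyl group itself, and a carboxylic acid, a primary amide or an aminomethyl group at this place would help to separate the two. Compound 3 carries a hydroxymethyl group here but also differs from compound 1 and compound 2 in a second place, so it gives no one-place comparison.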